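Swapping Chloro for Hydroxy on the Aryl Urea

The source may report more compounds than this note shows. Statements on the series, on what has been measured and on what is new or still open speak of the compounds shown alone.

Compound 1 `COc1cc(NC(C)CCCNC(=O)Nc2ccc(O)cc2)c2ncccc2c1`: 5200 nM
Compound 2 `COc1cc(NC(C)CCCNC(=O)NNC(=O)Nc2cccc(Cl)c2)c2ncccc2c1`: 220 nM
Compound 3 `COc1cc(NC(C)CCCNC(=O)Nc2cccc(Cl)c2)c2ncccc2c1`: 11000 nM

All three share one core and differ only in the group attached to the urea nitrogen. In a functional assay on MCF7 cells (Homo sapiens) for inhibition, read by MTT assay, with a stated time of 72 h (on this read-out higher numbers stand for weaker inhibition and lower numbers for stronger inhibition), compound 3 gives 11000 nM, the highest of the three numbers; compound 1 lies nearest with 5200 nM, and compound 2 is furthest away at 220 nM, the step being a 50-fold higher number from compound 2 to compound 3 (1.70 log units; beyond the scatter).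

Compound 4 `COc1cc(NC(C)CCCNC(=O)Nc2cccc(O)c2)c2ncccc2c1` is not yet measured. It differs from compound 3 by hydroxy in place of chloro on an aromatic carbon.

Going by the values given here, one measured step bears on this: compound 1 to compound 3, which exchanged 4-hydroxyphenyl for 3-chlorophenyl and gave a 2.1-fold higher number from compound 1 to compound 3 (0.33 log units; beyond the scatter). Among the compounds with values here, compound 4 carries 3-hydroxyphenyl, so that step is the only guide, and it was modest. The expectation is therefore a modest move back toward a lower number in this assay, a 1.8-fold lower number from compound 3 to compound 4 (0.26 log units; within the scatter), with room for no change beyond the scatter. Compound 4 is estimated at 6000 nM, within 2500 nM to 15000 nM.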

Compound 4, half-maximal inhibitory concentration: 11000 nM
Estimate against measurement, compound 4: 1.8-fold (0.26 log units) below; the measured number falls inside the stated range.
By their numbers in this assay, from the lowest: compound 2; then compound 1; then compounds 3 and 4 (each within the scatter of the next).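

On this aromatic carbon, hydroxy and chloro cannot be told apart in this assay, with no change at the digits printed from compound 3 to compound 4 (within the scatter), so this exchange does not by itself account for any of the larger differences in the series. The other two steps put the change in scale: the 3-hydroxyphenyl and 4-hydroxyphenyl compounds are separated by a 2.1-fold higher number from compound 1 to compound 4 (0.33 log units; beyond the scatter), while replacing the ((3-chlorophenyl)carbamoyl)amino group with 3-hydroxyphenyl gives a 50-fold higher number from compound 2 to compound 4 (1.70 log units; beyond the scatter), so the large shift appears only with that longer group. Nothing measured here explains why these steps differ in size.

From the compounds shown here alone, whether an amine or a carboxylic acid on the same carbon would also leave the number unchanged remains open. Going by these compounds, it is also open whether the ((3-chlorophenyl)carbamoyl)amino group would keep its advantage with hydroxy in place of its chloro.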